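Replacing cyclohexyl with 4-methylphenyl on the amine nitrogen

The compounds below may be only part of what the source reports. "The series", "measured", "known", "first", "only" and "open" are said of these compounds alone.

Three compounds share one core and differ only in the group on the amine nitrogen. Compound 1 `O=C1C(Nc2ccccc2F)=CC(=O)c2c1nc1n2[C@H]2OC[C@@H](O)[C@H]2OC1` carries a 2-fluorophenyl there; in a functional assay on ECa-109 cells for inhibition, with ECa-109 cell line (Homo sapiens) as the target, read by sulforhodamine B assay (on this read-out lower numbers stand for stronger inhibition and higher numbers for weaker inhibition), compound 1 gives 2660 nM. Compound 3 `COc1ccc(NC2=CC(=O)c3c(nc4n3[C@H]3OC[C@@H](O)[C@H]3OC4)C2=O)cc1` carries a 4-methoxyphenyl, and in this assay compound 3 gives 3410 nM. The step of a 1.3-fold higher number from compound 1 to compound 3 (0.11 log units; within the scatter) shows that exchanging one of these two groups for the other lies within the usual scatter. Compound 2 `O=C1C=C(NC2CCCCC2)C(=O)c2c1nc1n2[C@H]2OC[C@@H](O)[C@H]2OC1` carries a cyclohexyl instead. For compound 2 only a limit is known: in this assay compound 2 gives > 16000 nM, which is the limit of > 16000 nM in this assay, at which 1 of the 3 values shown sits, and not a number. Compound 4 `Cc1ccc(NC2=CC(=O)c3nc4n(c3C2=O)[C@H]2OC[C@@H](O)[C@H]2OC4)cc1` is not yet measured. It differs from compound 2 by 4-methylphenyl in place of cyclohexyl on an amine nitrogen, so that cyclohexylamino becomes (4-methylphenyl)amino. Going by the values given here, no measured step covers this exchange, since compound 2 has only a limit; the one measured step, a 1.3-fold higher number from compound 1 to compound 3 (0.11 log units; within the scatter), concerns two phenyl groups. Because compound 1 gives 2660 nM and compound 3 gives 3410 nM, both actual numbers, compound 4 is expected to return to their range, a step of an at least 5.3-fold lower number from compound 2 to compound 4 (0.72 log units; beyond the scatter). Compound 4 is therefore estimated at 3000 nM, between 1200 nM and 8000 nM.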

Compound 4, half-maximal inhibitory concentration: 3480 nM
Beside the measured number, compound 4's estimate is 1.2-fold (0.06 log units) below it; the range from low to high includes it.
By their numbers in this assay, from the lowest: compounds 1, 3 and 4 (each within the scatter of the next). At a limit, above all of these: compound 2.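

Going by these compounds alone, at this amine nitrogen, exchanging cyclohexyl for 4-methylphenyl gives an at least 4.5-fold lower number from compound 2 to compound 4 (0.66 log units; beyond the scatter) in this assay, so the position responds to the group it carries, which the one step between two phenyl groups could not show. The size of this step is only a minimum, because compound 2 stands at a limit and not at a number: the limit of > 16000 nM in this assay, at which 1 of the 4 values shown sits. Compound 4 joins compound 1 and compound 3, with the three values each within the scatter of the next, so among these three substituted phenyl groups the choice of group shows no clear effect.

From the compounds shown here alone, whether an unsubstituted phenyl, a benzyl or a straight alkyl chain on this nitrogen would read like these three or like compound 2 stays open. With a single non-aromatic group shown, it is also open whether the ring type or the added methyl accounts for the step.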